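Series notes: aryl replacements on the shared core

The source may hold more compounds than are shown below. What is called first, only, known or untested is meant among the compounds shown, and "the series" means these compounds.

Measured compounds:
Compound 1, `CC(C)c1noc(N2CCC(Oc3cc(N4CCc5cc(N6CCCCC6=O)ccc54)ncn3)CC2)n1`, in an assay on CHO cells for agonist activity at Glucose-dependent insulinotropic receptor (Homo sapiens), read by a luciferase reporter and cAMP accumulation, with a stated time of 2 h (a higher number here means that more compound is needed for the effect, a lower number that less compound is needed), gives 17 nM.
Compound 2, `CC(C)c1noc(N2CCC(Oc3cc(N4CCc5cc(C6CCCCC6=O)ccc54)ncn3)CC2)n1`, in this assay gives 48 nM.
Compound 3, `CC(C)c1noc(N2CCC(Oc3cc(N4CCc5cc([S+]([O-])CCO)ccc54)ncn3)CC2)n1`, in this assay gives 48 nM.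

Compound 1 gives the lowest number of the three; both other compounds sit beyond the scatter from it, a 2.8-fold higher number from compound 1 to compound 2 (0.45 log units; beyond the scatter) and a 2.8-fold higher number from compound 1 to compound 3 (0.45 log units; beyond the scatter), while compound 2 and compound 3 show no change at the digits printed from compound 2 to compound 3 (within the scatter).

Compound 4, `CC(C)c1noc(N2CCC(Oc3cc(N4CCc5cc(S(=O)(=O)CCO)ccc54)ncn3)CC2)n1`, has not been measured. It differs from compound 1 in one place: (2-hydroxyethyl)sulfonyl in place of 2-oxopiperidin-1-yl on an aromatic carbon. Going by the values given here, the step that bears most directly on this change is the one to compound 3, since there too the 2-oxopiperidin-1-yl group is replaced by a chain carrying sulfur and a hydroxyl; that step was modest and beyond the scatter. The step to compound 2 points the same way and with the same size. A modest rise in the number is therefore expected for compound 4 in this assay, roughly a 2.6-fold higher number from compound 1 to compound 4 (0.42 log units; beyond the scatter), because a 2.8-fold higher number from compound 1 to compound 3 (0.45 log units; beyond the scatter) came from the closest change on record. The estimate for compound 4 is 45 nM, with a range of 20 nM to 110 nM.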

Compound 4, half-maximal effective concentration: 41 nM
Compound 4: middle estimate off by 1.1-fold (0.04 log units), on the high side, within the range that was stated.
By their numbers in this assay, from the lowest: compound 1; then compounds 4, 2 and 3 (each within the scatter of the next).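

In this assay, three quite different replacements now all give a higher number than the 2-oxopiperidin-1-yl group, and (2-hydroxyethyl)sulfonyl is the third of them (a 2.4-fold higher number from compound 1 to compound 4 (0.38 log units; beyond the scatter)). The additional oxygen of the sulfonyl group leaves no readable difference (a 1.2-fold lower number from compound 3 to compound 4 (0.07 log units; within the scatter)), and the open sulfur chain cannot be told apart from the carbon-only ring of the 2-oxocyclohexyl group (a 1.2-fold lower number from compound 2 to compound 4 (0.07 log units; within the scatter)). No measurement on hand bears on the reason for these numbers.

Going by these compounds, it remains open whether the hydroxyl group of the sulfur chains contributes at all, which methylsulfonyl or 3-hydroxypropylsulfonyl would test. Also open, on these data alone, is how much of the 2-oxopiperidin-1-yl result depends on the ring itself, which 2-oxopyrrolidin-1-yl or an open-chain N-methylacetamide would address.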